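Swapping Fluorine for Bromine on the Benzyl Group

This account rests on a few compounds, and the source may have more. Where it says the series, first, only, none or still open, it means among the compounds named here.

Compound 3 `O=c1ccoc2cc(OCc3cn(Cc4ccc(F)cc4)nn3)ccc12` was tested in a functional assay on HeLa cells (Homo sapiens) for cytotoxicity, read by MTT assay, with a stated time of 48 h (a lower number here means a stronger inhibitor, a higher number a weaker inhibitor), where compound 3 gives 12000 nM. Its closest relative, compound 2 `O=c1ccoc2cc(OCc3cn(Cc4cccc(F)c4)nn3)ccc12`, gives 7550 nM in this assay; the step of a 1.6-fold higher number from compound 2 to compound 3 (0.20 log units; within the scatter) places the two side by side, so compound 3 carries the highest of the two measured numbers only in name. Compound 1 `O=c1ccoc2cc(OCc3cn(Cc4cccc(Br)c4)nn3)ccc12` reaches only the assay limit of > 100000 nM in this assay, a limit and not a number.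

Compound 4 `O=c1ccoc2cc(OCc3cn(Cc4ccc(Br)cc4)nn3)ccc12` differs from compound 3 in one place: bromo in place of fluoro on an aromatic carbon. The measured steps that bear on this swap run the other way: an at least 13-fold lower number from compound 1 to compound 2 (1.12 log units; beyond the scatter) and an at least 8.3-fold lower number from compound 1 to compound 3 (0.92 log units; beyond the scatter), both beyond the scatter, each showing that putting fluoro where bromo stood gave a much lower number. Reversing that exchange on compound 3 should therefore raise the number by a large step, quite possibly back to the limit, with a fair chance that only a limit is reported. Compound 4 is expected to give 90000 nM, between 25000 nM and 300000 nM, a step of a 7.5-fold higher number from compound 3 to compound 4 (0.88 log units; beyond the scatter).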

Compound 4, half-maximal inhibitory concentration: > 100000 nM
Compound 4 gave a limit, no number; the forecaster's own chance of this, stated with the estimate: 50%; middle value at least 1.1-fold (0.04 log units) away from the limit.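

Bromo in place of fluoro on the 4-fluorobenzyl group gives an at least 8.3-fold higher number from compound 3 to compound 4 (0.92 log units; beyond the scatter) in this assay, so the loss seen earlier for the bromo compound 1 also appears with the halogen para to a large group. The change from the 3-fluorophenyl group of compound 2 to the 4-bromophenyl group points the same way, with an at least 13-fold higher number from compound 2 to compound 4 (1.12 log units; beyond the scatter). With compound 4 in hand, there are now two matched pairs that differ only in fluoro and bromo, and they agree in direction: the same change on two cores in this assay, an at least 13-fold lower number (1.12 log units; beyond the scatter) from compound 1 to compound 2 and an at least 8.3-fold lower number (0.92 log units; beyond the scatter) from compound 4 to compound 3; the limit leaves it open whether they differ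

Compound 1 and compound 4 both carry a limit, and the step between them cannot be read, which leaves open whether the place of the bromo matters. As far as these compounds go, it also remains open how a chloro or a methoxy group on this same aromatic carbon would compare with fluoro and bromo.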